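A few compounds are considered here, and "the series" means these few. Any claim that something is new, unique, unknown or untested is made for them only; others in the source may bear on it.

In an ADME assay on HEK293 cells (Homo sapiens) for cytotoxicity, read by MTT assay, with a stated time of 72 h (a lower number here means a stronger inhibitor, a higher number a weaker inhibitor), the measured compounds are these:
- Compound 1 `COc1ccc(C2=C(c3cc(OC)c(OC)c(OC)c3)C(=O)CC2O[SiH2]C(C)(C)C)cc1` gives > 100 ug/mL as a limit of the assay
- Compound 2 `COc1ccc(OC)c(C2=C(c3cc(OC)c(OC)c(OC)c3)C(=O)CC2O[SiH2]C(C)(C)C)c1` gives 9.5 ug/mL as a number
- Compound 3 `COc1cc(C2=C(c3cc(C)c(OC)c(C)c3)C(OC(C)=O)CC2=O)cc(OC)c1OC` gives > 100 ug/mL as a limit of the assay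

Among the compounds with values here, compound 2 holds the only true number of the three. Compound 1 and compound 3 both stand at the limit of > 100 ug/mL in this assay, at which 2 of the 3 values shown sit, and so give no number.

Compound 4 `COC(=O)c1cc(C2=C(c3cc(OC)c(OC)c(OC)c3)C(=O)CC2O[SiH2]C(C)(C)C)ccc1OC` has not yet been measured and departs from compound 2 in one place: 4-methoxy-3-(methoxycarbonyl)phenyl in place of 2,5-dimethoxyphenyl on a double-bonded ring carbon on a double-bonded ring carbon, where 4-methoxy-3-(methoxycarbonyl)phenyl stands in place of 2,5-dimethoxyphenyl.

Within the data shown here, the one measured step at this carbon is an at least 10-fold lower number from compound 1 to compound 2 (1.02 log units; beyond the scatter) and it is large, beyond the scatter. That step brought in the 2,5-dimethoxyphenyl that compound 4 gives up, while the entering group keeps the 4-methoxy of the 4-methoxyphenyl in compound 1. Part of that drop may therefore be undone, so a move to a higher number is expected in this assay rather than a move to a lower one. The estimated size is a 4.2-fold higher number from compound 2 to compound 4 (0.62 log units; beyond the scatter) and a reading at the limit remains quite possible. The estimate for compound 4 is 40 ug/mL with an expected range from 10 ug/mL to 100 ug/mL once it is measured.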

Compound 4, half-maximal inhibitory concentration: > 100 ug/mL
Compound 4: only a limit was reported (the forecaster's own chance of this, stated with the estimate: 40%); middle value at least 2.5-fold (0.39 log units) away from the limit.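

In this assay, 4-methoxy-3-(methoxycarbonyl)phenyl in place of 2,5-dimethoxyphenyl on the double-bonded ring carbon gives an at least 10-fold higher number from compound 2 to compound 4 (1.02 log units; beyond the scatter), and since the reading of compound 4 is a limit, the true size of this step may be larger. Together with an at least 10-fold lower number from compound 1 to compound 2 (1.02 log units; beyond the scatter), this leaves compound 2 alone among the three compounds that differ at this carbon in giving a true number, while 4-methoxyphenyl in compound 1 and the new group in compound 4 both end at the limit. The step that adds methoxycarbonyl in place of hydrogen on an aromatic carbon, from compound 1 to compound 4, cannot be read, so any effect of the methoxycarbonyl alone stays hidden, with both compounds sitting at this line: the limit of > 100 ug/mL in this assay, at which 3 of the 4 values shown sit.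

On these data alone, it remains open whether a carboxylic acid, an amide or an amine in place of the methoxycarbonyl would bring the number back toward that of compound 2. As far as these compounds go, it is also open whether both methoxy groups of the 2,5-dimethoxyphenyl are needed, or whether a single methoxy group in a different place, or a chloro group, would serve as well.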